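Replacing the Bromo Group on a Fused Bicyclic Core

A few compounds are considered here, and "the series" means these few. Any claim that something is new, unique, unknown or untested is made for them only; others in the source may bear on it.

Measured compounds in a functional assay on 786-0 cells (Homo sapiens) for inhibition, read by sulforhodamine B assay, with a stated time of 48 h, tested at 10 uM; a higher number here means more inhibition at the concentration tested (going by the name of the read-out), a lower number less inhibition:
compound 1 `Brc1cn2ccnc2c(-c2ccc3ncn(C4CCCCC4)c3c2)n1`: 10%
compound 2 `c1ccc(-c2cn3ccnc3c(-c3ccc4ncn(C5CCCCC5)c4c3)n2)cc1`: 36.8%
compound 3 `O=Cc1ccc(-c2cn3ccnc3c(-c3ccc4ncn(C5CCCCC5)c4c3)n2)cc1`: 46.7%

Compound 1 stands lowest of the three numbers in this assay. Its nearest neighbour is compound 2, reached by a number 26.8 percentage points higher from compound 1 to compound 2 (beyond the scatter), and its furthest is compound 3, reached by a number 36.7 percentage points higher from compound 1 to compound 3 (beyond the scatter). Between compound 2 and compound 3 the step is a number 9.9 percentage points higher from compound 2 to compound 3 (within the scatter), so the two aryl-bearing compounds cannot be told apart.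

Compound 4 `COc1ccccc1-c1cn2ccnc2c(-c2ccc3ncn(C4CCCCC4)c3c2)n1` has not been measured. It differs from compound 1 in one place: 2-methoxyphenyl in place of bromo on an aromatic carbon. The two steps that bear on this change both put an aromatic ring where the bromo sat, and both raised inhibition beyond the scatter, by a modest to large amount. Among the measured compounds shown here, a further methoxy on that ring has no precedent here, and the step from compound 2 to compound 3 suggests that a substituent on the new ring need not move the number much. Compound 4 is therefore expected to show a rise of a number 26 percentage points higher from compound 1 to compound 4 (beyond the scatter), landing near 36%, with a range from 15% to 55%.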

Compound 4, a percentage reported as inhibition, at one concentration (the size of the read-out at that concentration, not a potency): 12.3%
Compound 4: middle estimate off by 23.7 percentage points, on the high side, and the stated range ends above it.
By their numbers in this assay, from the lowest: compounds 1 and 4 (each within the scatter of the next); then compounds 2 and 3 (each within the scatter of the next).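

In this assay, placing an aromatic ring where the bromo sat does not by itself raise inhibition: with 2-methoxyphenyl at this position the step is a number 2.3 percentage points higher from compound 1 to compound 4 (within the scatter) and stays level with the bromo compound. The substituted ring therefore matters, since adding methoxy to the phenyl group gives a number 24.5 percentage points lower from compound 2 to compound 4 (beyond the scatter) and exchanging 4-formylphenyl for 2-methoxyphenyl gives a number 34.4 percentage points lower from compound 3 to compound 4 (beyond the scatter), so a substituent on the new ring can remove the gain seen with the other aryl compounds. Nothing available here gives a reason for this loss.

The compounds shown leave open whether the loss follows the methoxy group itself or its place on the ring, which a 4-methoxyphenyl group would address. They also leave open how a 2-methylphenyl group or an aminophenyl group would read at this position.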